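The compounds below may be only part of what the source reports. "The series", "measured", "known", "first", "only" and "open" are said of these compounds alone.

Compound 1 `C#CCN(CCCCCCN1C(=O)c2ccccc2C1=O)Cc1ccccc1OC` — 9100 nM in an assay on cells for inhibition of Amine oxidase [flavin-containing] B (Homo sapiens), read by fluorescence, with a stated time of 30 min; a lower number here means a stronger inhibitor, a higher number a weaker inhibitor
Compound 2 `CCN(CCCCCCN1C(=O)c2ccccc2C1=O)Cc1ccccc1OC` — 11700 nM in this assay

Only these two compounds have been measured so far. Compound 2 gives the higher of the two numbers, but the step of a 1.3-fold higher number from compound 1 to compound 2 (0.11 log units; within the scatter) is within the scatter, so the two values cannot be told apart. Compound 3 `COc1ccccc1CN(C)CCCCCCN1C(=O)c2ccccc2C1=O` has not yet been measured. It differs from compound 2 in one place: hydrogen in place of methyl on a saturated chain carbon bound to an amine nitrogen. The same substituent is shortened once more, seen from the amine nitrogen outward, along the line that already led from compound 1 to compound 2.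

Among the compounds with values here, the only step that bears on this change is the step from compound 1 to compound 2, and that step was a 1.3-fold higher number from compound 1 to compound 2 (0.11 log units; within the scatter), within the scatter. There is nothing in the measured pair that points to a shift in this assay beyond the scatter, in either direction, when the chain on that carbon is cut down further. The step from compound 2 to compound 3 is therefore expected to be a 1.1-fold higher number from compound 2 to compound 3 (0.05 log units; within the scatter). For compound 3 the estimate is 13000 nM, with a range from 5000 nM to 35000 nM.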

Compound 3, half-maximal inhibitory concentration: 11300 nM
The estimate for compound 3 lay 1.2-fold (0.06 log units) above the measured number; measured number inside the range.
By their numbers in this assay, from the lowest: compounds 1, 3 and 2 (each within the scatter of the next).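

Going from ethyl to methyl at this place, with hydrogen in place of methyl on a saturated chain carbon bound to an amine nitrogen, gives a 1.0-fold lower number from compound 2 to compound 3 (0.02 log units; within the scatter) in this assay and so adds a second step that cannot be told from zero. Hydrogen in place of ethynyl at the same place gives a 1.2-fold higher number from compound 1 to compound 3 (0.09 log units; within the scatter) and so shows that, across all three compounds, this assay does not separate a substituent that carries the ethynyl end from the two shorter ones, whereas the earlier pair could speak only for ethynyl against methyl. No measurement here explains why these changes leave the number within the scatter.

Whether any group at this place can move the number beyond the scatter stays open, since a hydrogen directly on the amine nitrogen, a longer chain such as butyl, and a benzyl group do not appear among these compounds. The three compounds also share the rest of their structure, so they say nothing about how the number responds to changes elsewhere, such as in the length of the chain that joins the amine to the shared core.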